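From 2,5-difluorophenyl to 3-methylphenyl in compound 4

The source may hold more compounds than are shown below. What is called first, only, known or untested is meant among the compounds shown, and "the series" means these compounds.

In a functional assay on A549 cells (Homo sapiens) for antiproliferative activity, read by MTT assay, with a stated time of 72 h (on this read-out higher numbers stand for weaker inhibition and lower numbers for stronger inhibition), compound 3 `COc1cc(-n2cnc3ccc(-c4cc(F)ccc4F)cc32)cc(OC)c1OC` gives 7940 nM. Compound 1 `CCOc1ccc(-c2ccc3ncn(-c4cc(OC)c(OC)c(OC)c4)c3c2)cc1` gives 8550 nM, which lies within the scatter of the value for compound 3. Compound 2 `COc1cc(-n2cnc3ccc(-c4ccccc4Cl)cc32)cc(OC)c1OC` is reported only as a limit, > 10000 nM.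

Compound 4 `COc1cc(-n2cnc3ccc(-c4cccc(C)c4)cc32)cc(OC)c1OC` keeps the shared core of compound 3 and changes one group on an aromatic carbon, with 3-methylphenyl in place of 2,5-difluorophenyl on an aromatic carbon.

The closest evidence comes from the other swaps of this same group. These are a 1.1-fold lower number from compound 1 to compound 3 (0.03 log units; within the scatter), an at least 1.1-fold higher number from compound 1 to compound 2 (0.06 log units; that floor lies within the scatter) and an at least 1.2-fold lower number from compound 2 to compound 3 (0.10 log units; that floor lies within the scatter). None of them shows a change beyond the scatter, although the two involving compound 2 rest on a limit and give only a floor.

No shift beyond the scatter is therefore expected in this assay, and the expected change is a 1.1-fold higher number from compound 3 to compound 4 (0.03 log units; within the scatter). For compound 4 the estimated value is 8500 nM, with an expected range of 4000 nM to 16000 nM.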

Compound 4, half-maximal inhibitory concentration: 3820 nM
The estimate for compound 4 lay 2.2-fold (0.35 log units) above the measured number; the whole stated range lies above it.
By their numbers in this assay, from the lowest: compound 4; then compounds 3 and 1 (each within the scatter of the next). At a limit, above all of these: compound 2.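

Swaps of the phenyl group on this aromatic carbon can move the number in this assay after all: a 2.1-fold lower number from compound 3 to compound 4 (0.32 log units; beyond the scatter) and a 2.2-fold lower number from compound 1 to compound 4 (0.35 log units; beyond the scatter), whereas the swaps among the first three compounds stayed within the scatter. The third new step, an at least 2.6-fold lower number from compound 2 to compound 4 (0.41 log units; beyond the scatter), gives only a floor and not a size. Compound 2 is known only as a limit: the limit of > 10000 nM in this assay, at which 1 of the 4 values shown sits.

The compounds shown leave open whether the lower number belongs to the methyl group itself or to where it sits on the phenyl ring, a question that a plain phenyl or a 4-methylphenyl would speak to. They also leave open what a different group at that place on the ring, such as an amine or a carboxylic acid, would do to the number.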